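The source may report more compounds than this note shows. Statements on the series, on what has been measured and on what is new or still open speak of the compounds shown alone.

Of the compounds shown here, three sharing one core have been measured in a functional assay on DLD-1 cells (Homo sapiens) for cytotoxicity, read by MTT assay, with a stated time of 72 h; a lower number here means a stronger inhibitor, a higher number a weaker inhibitor. Compound 1 `Cc1c(/N=C/c2ccccc2Cl)c(=O)n(-c2ccccc2)n1C` gives 417000000 nM. Compound 2 `COc1cccc(/C=N/c2c(C)n(C)n(-c3ccccc3)c2=O)c1` gives in this assay 832000000 nM, and compound 3 `COc1ccccc1/C=N/c1c(C)n(C)n(-c2ccccc2)c1=O` gives in this assay 933000000 nM. Compound 3 thus shows the highest number of the three, but its nearest neighbour, compound 2, lies within the scatter of it, as a 1.1-fold higher number from compound 2 to compound 3 (0.05 log units; within the scatter) shows; only the gap to compound 1, a 2.2-fold higher number from compound 1 to compound 3 (0.35 log units; beyond the scatter), lies beyond it. Compound 4 `Cc1c(/N=C/c2ccccc2)c(=O)n(-c2ccccc2)n1C` has not yet been measured; it differs from compound 3 by hydrogen in place of methoxy on an aromatic carbon. Within the data shown here, no measured step removes a substituent outright, so the steps that bear on it are indirect: a 2.2-fold higher number from compound 1 to compound 3 (0.35 log units; beyond the scatter) exchanges one group for another on an aromatic carbon, and a 2.0-fold higher number from compound 1 to compound 2 (0.30 log units; within the scatter) replaces one substituted ring with another, both small. Every measured change on this ring stayed at or close to the scatter. Compound 4 is therefore expected to move little in this assay, with at most a modest shift downward, a step of a 1.3-fold lower number from compound 3 to compound 4 (0.12 log units; within the scatter). Compound 4 is accordingly estimated at 700000000 nM, with a range from 300000000 nM to 1600000000 nM.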

Compound 4, half-maximal inhibitory concentration: 933000000 nM
Compound 4: the middle estimate sits 1.3-fold (0.12 log units) below what was measured, within the range that was stated.
By their numbers in this assay, from the lowest: compounds 1, 2, 3 and 4 (each within the scatter of the next, the first and the last beyond it).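

In this assay taking the methoxy group off the ring, the change from 2-methoxyphenyl to phenyl, gives no change at the digits printed from compound 3 to compound 4 (within the scatter) and the same exchange on the other methoxy compound gives a 1.1-fold higher number from compound 2 to compound 4 (0.05 log units; within the scatter) so the bare phenyl ring cannot be told apart from either methoxyphenyl ring. Hydrogen in place of chloro gives a 2.2-fold higher number from compound 1 to compound 4 (0.35 log units; beyond the scatter) and is the only exchange for hydrogen that passes the scatter, yet this gap remains modest, and compound 2 still lies within the scatter of compound 1, so the four compounds form one narrow band rather than clear steps. Nothing available here gives a reason for these small differences.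

The compounds shown leave open whether the small gap seen with chloro depends on where that group sits on the ring, or holds for other halogens such as fluoro or bromo. They also leave open whether an amine, a carboxylic acid or a longer alkyl chain on this ring, or any change to the second phenyl ring or the two methyl groups of the shared core, would move the number well outside this band.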